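Swapping Chloro for Fluoro on a Nicotinic Ligand

A few compounds are considered here, and "the series" means these few. Any claim that something is new, unique, unknown or untested is made for them only; others in the source may bear on it.

Going by the values given here, compound 2 `CN1[C@H](COc2ccc(Cl)nc2)C[C@H]2C[C@H]21` is the one compound here with a measured number: in an assay on CHO-K1 cells for displacement of a labelled ligand from Neuronal acetylcholine receptor; alpha4/beta2 (Homo sapiens), read by scintillation counting (a lower number here means a stronger inhibitor, a higher number a weaker inhibitor), compound 2 gives 3.4 nM. Compound 1 `CC(=O)N1[C@H](COc2ccc(Cl)nc2)C[C@H]2C[C@H]21`, which carries an acetyl instead of a methyl on the ring amine, reaches a limit of the assay, > 10000 nM, in this assay. Among the compounds with values here, the single measured step, an at least 2900-fold lower number from compound 1 to compound 2 (3.46 log units; beyond the scatter), therefore rests on that limit of > 10000 nM in this assay, at which 1 of the 2 values shown sits, and concerns the amine nitrogen, not the aromatic ring.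

Compound 3 `CN1[C@H](COc2ccc(F)nc2)C[C@H]2C[C@H]21` differs from compound 2 elsewhere: fluoro in place of chloro on an aromatic carbon. Within the data shown here, none of the measured steps touches this halogen, so there is no direct guide for this assay; the large step from compound 1 to compound 2 speaks only for the amine. A swap of one small halogen for another on the same aromatic carbon is expected to move the number modestly, if at all, so compound 3 is estimated at 6 nM, with a range from 1.5 nM to 25 nM. That estimate means an expected step of a 1.8-fold higher number from compound 2 to compound 3 (0.25 log units; within the scatter), likely within the scatter.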

Compound 3, inhibition constant: 1.1 nM
Estimate against measurement, compound 3: 5.5-fold (0.74 log units) above; the measured number lies below the stated range.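

The halogen on the aromatic carbon next to the ring nitrogen turns out to matter: in this assay, fluoro in place of chloro gives a 3.1-fold lower number from compound 2 to compound 3 (0.49 log units; beyond the scatter) and so a real, if modest, gain. Until now the only step shown concerned the ring amine, so this is the first sign that the aromatic ring, too, can shift the number. It also shows that this position accepts the exchange of one halogen for another without any loss in binding, and that the smaller of the two atoms gives the lower number in this pair. Nothing shown here accounts for the direction or size of this step.

From the compounds shown here alone, two halogens do not make a trend, so it stays open how a hydrogen, a bromo, a methyl or a nitrile on the same aromatic carbon would read in this assay and whether any of them would go beyond fluoro. Also open, going by these compounds, is whether fluoro would keep its advantage over chloro with a group other than methyl on the ring amine, such as an ethyl.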